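The compounds below may be only part of what the source reports. "The series", "measured", "known", "first", "only" and "open" are said of these compounds alone.

Measured in an assay on isolated protein for inhibition of Rho-associated protein kinase 2 (Homo sapiens), read by radiometric assay; a higher number here means a weaker inhibitor, a lower number a stronger inhibitor:
Compound 1 `NCc1ccc(C(=O)Nc2ccncc2F)cc1-c1cccc(C(=O)Oc2ccccc2)c1` gives 6.2 nM.
Compound 2 `NCc1ccc(C(=O)Nc2ccncc2)cc1-c1cccc(C(=O)OCC2CCCCC2)c1` gives 48 nM.
Compound 3 `NCc1ccc(C(=O)Nc2ccncc2F)cc1-c1cccc(C(=O)OCC2CCCC2)c1` gives 13 nM.

Compound 2 stands highest of the three numbers in this assay; compound 3 lies nearest to it and compound 1 furthest, both gaps beyond the scatter. Compound 4 `COC(=O)c1cccc(-c2cc(C(=O)Nc3ccncc3)ccc2CN)c1` differs from compound 2 by hydrogen in place of cyclohexyl on a saturated chain carbon bound to an oxygen next to a carbonyl group, which read one bond further out is cyclohexylmethoxycarbonyl to methoxycarbonyl. Going by the values given here, no measured step alters this ester in the same way. Among the compounds with values here, the only single-point step known, a 2.1-fold higher number from compound 1 to compound 3 (0.32 log units; beyond the scatter), exchanges one ester group for another of comparable size and shifts the number only modestly. Within the data shown here, compound 2 differs from compounds 1 and 3 in more than one place, so their values show only that compound 2 sits higher. Cutting the ester down to methyl is thus untested, and the expected step is small, in either direction, leaning toward a higher number. The estimate for compound 4 in this assay is 70 nM, with a range of 25 nM to 200 nM, a step of a 1.5-fold higher number from compound 2 to compound 4 (0.16 log units; within the scatter) being expected.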

Compound 4, half-maximal inhibitory concentration: 2.9 nM
Beside the measured number, compound 4's estimate is 24-fold (1.38 log units) above it, and the stated range ends above it.
By their numbers in this assay, from the lowest: compound 4; then compound 1; then compound 3; then compound 2.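

In this assay, going by these compounds alone, the change from cyclohexylmethoxycarbonyl to methoxycarbonyl gives (a 17-fold lower number from compound 2 to compound 4 (1.22 log units; beyond the scatter)), which shows that this ester position can carry a large shift, whereas the one earlier step there was modest (a 2.1-fold higher number from compound 1 to compound 3 (0.32 log units; beyond the scatter)). Losing the cyclohexyl group lowers the number, so a low number at this position does not depend on that ring, and a group as small as methyl is enough. Nothing measured here bears on why the number falls.

From the compounds shown here alone, whether an ethyl ester, a carboxylic acid or an amide at this position would hold a number as low remains open. Also open, going by these compounds, is whether the same cut would act alike on the core of compound 3, which differs from compound 4 in more than one place.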